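The compounds below may be only part of what the source reports. "The series", "measured", "known", "first", "only" and "open" are said of these compounds alone.

Measured so far in a functional assay on CHO cells for antagonist activity at C-X-C chemokine receptor type 3 (Homo sapiens), read by GTPgammaS binding, with a stated time of 30 min; a higher number here means a weaker inhibitor, a lower number a stronger inhibitor:
- compound 1 `O=C1CCC(c2ccccn2)(C2CCN(Cc3ccc(Br)cc3)CC2)C(=O)N1` gives 500 nM
- compound 2 `O=C1CCC(c2ccncc2)(C2CCN(Cc3ccc(Br)cc3)CC2)C(=O)N1` gives 630 nM
- compound 3 `O=CN1CCCC(c2ccccc2)(C2CCN(Cc3ccc(Br)cc3)CC2)C1` gives 150 nM

Compound 3 stands lowest of the three numbers. Its nearest neighbour is compound 1, with a gap beyond the scatter, and the gap to compound 2 is wider still, also beyond the scatter. Compound 3 also carries a different core from compounds 1 and 2, so the two cores cannot be compared on a single change.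

Compound 4 `CCC(=O)N1CCCC(c2ccccc2)(C2CCN(Cc3ccc(Br)cc3)CC2)C1` is the next step from compound 3. The change is ethyl in place of hydrogen on a carbonyl carbon. Within the data shown here, no measured pair carries this kind of change. Among the measured compounds shown here, the only measured step, a 1.3-fold higher number from compound 1 to compound 2 (0.10 log units; within the scatter), concerns a pyridyl swap on the other core and lies within the scatter, so it gives no direct guidance on what acyl growth at the ring nitrogen does in this assay.

With nothing comparable on hand, compound 4 is expected to stay close to compound 3, a step of a 1.1-fold higher number from compound 3 to compound 4 (0.03 log units; within the scatter), with a wide range to reflect the lack of a precedent. The estimate for compound 4 in this assay is 160 nM, expected to fall between 55 nM and 480 nM.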

Compound 4, half-maximal inhibitory concentration: 290 nM
Beside the measured number, compound 4's estimate is 1.8-fold (0.26 log units) below it; measured number inside the range.
By their numbers in this assay, from the lowest: compounds 3, 4, 1 and 2 (each within the scatter of the next, the first and the last beyond it).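

In this assay, among these compounds, the first change in one place on the core of compound 3 gives a 1.9-fold higher number from compound 3 to compound 4 (0.29 log units; within the scatter), with ethyl in place of hydrogen on a carbonyl carbon whose other neighbours are an amide-type nitrogen in a ring. Formyl to propanoyl therefore leaves compound 3 and compound 4 inseparable in this read-out, showing that this position accepts ethyl with no difference that can be told from the usual scatter, something the pyridyl swap on the core of compound 1 could not show. No supporting data bear on why this substitution gives this outcome.

From the compounds shown here alone, whether the same holds for a longer chain such as butyl, a branched group such as isopropyl, a cyclopropyl ring, or an ethyl chain ending in an amine or a carboxylic acid on this carbonyl carbon remains open. It is also open whether a phenyl group or a pyridyl group accounts for any part of the gap between the two cores, as no pair shown differs at that place alone.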